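The compounds below may be only part of what the source reports. "The series", "measured", "known", "first", "only" and "open" are said of these compounds alone.

Measured in a functional assay on MDA-MB-231 cells (Homo sapiens) for cytotoxicity, read by MTT assay, with a stated time of 72 h; a lower number here means a stronger inhibitor, a higher number a weaker inhibitor:

- compound 1 `O=C1c2c[n+]([O-])c3ccccc3c2C(=O)c2c1c1ccccc1n2CCCCn1ccnc1`: 210 nM
- compound 2 `O=C1c2c[n+]([O-])c3ccccc3c2C(=O)c2c1c1ccccc1n2CCCCN1CCNCC1`: 3310 nM
- compound 3 `O=C1c2c[n+]([O-])c3ccccc3c2C(=O)c2c1c1ccccc1n2CCCCN1CCCCC1`: 610 nM

Compound 3 stands in the middle of this short series, with 610 nM as the second highest number. It lies on one side of a 2.9-fold higher number from compound 1 to compound 3 (0.46 log units; beyond the scatter) and on the other of a 5.4-fold lower number from compound 2 to compound 3 (0.73 log units; beyond the scatter). Compound 4 `CCCN1CCN(CCCCn2c3c(c4ccccc42)C(=O)c2c[n+]([O-])c4ccccc4c2C3=O)CC1` keeps the shared core and the butyl-length chain but differs at its end: 4-propylpiperazin-1-yl in place of piperidin-1-yl on a saturated chain carbon, four bonds along the chain from an aromatic nitrogen. The most relevant measurement is a 5.4-fold lower number from compound 2 to compound 3 (0.73 log units; beyond the scatter), which exchanges the same two ring types at the same place, though compound 2 lacks the propyl substituent. The wider a 16-fold higher number from compound 1 to compound 2 (1.20 log units; beyond the scatter) shows that a change here can be large. Among the compounds with values here, no measured compound carries 4-propylpiperazin-1-yl, so its effect remains unknown. A modest move toward a higher number is therefore expected in this assay, smaller than the full gap between compound 3 and compound 2. The expected change is a 2.1-fold higher number from compound 3 to compound 4 (0.33 log units; beyond the scatter). For compound 4 the estimated value is 1300 nM, within an expected range of 450 nM to 3500 nM.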

Compound 4, half-maximal inhibitory concentration: 2980 nM
Beside the measured number, compound 4's estimate is 2.3-fold (0.36 log units) below it; low and high end bracket the measured number.
By their numbers in this assay, from the lowest: compound 1; then compound 3; then compounds 4 and 2 (each within the scatter of the next).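

In this assay a propyl on the amine nitrogen of the piperazine ring gives a 1.1-fold lower number from compound 2 to compound 4 (0.05 log units; within the scatter) so compound 2 and compound 4 cannot be ordered. Substituting that ring nitrogen with propyl therefore does not recover the lower number of the piperidin-1-yl compound: the change on this saturated chain carbon gives a 4.9-fold higher number from compound 3 to compound 4 (0.69 log units; beyond the scatter) and so the gap to piperidin-1-yl stays whether the piperazine nitrogen carries hydrogen or propyl. Against the 1H-imidazol-1-yl end the picture is the same, with a 14-fold higher number from compound 1 to compound 4 (1.15 log units; beyond the scatter) and compound 1 keeps the lowest number of the four.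

Nothing available explains why these end groups differ. The compounds shown also leave open how a morpholin-4-yl ring, an acetyl group on the piperazine nitrogen or a longer chain would read in this assay.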